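The source may report more compounds than this note shows. Statements on the series, on what has been measured and on what is new or still open speak of the compounds shown alone.

Measured so far:
- Compound 1 `COc1ccc(-c2nc(SCC(=O)c3sc(-c4ccccc4)nc3C)[nH]c(=O)c2C#N)cc1`: 76200 nM
- Compound 2 `Cc1nc(-c2ccc(Cl)cc2)sc1C(=O)CSc1nc(-c2ccc(Cl)c(Cl)c2)c(C#N)c(=O)[nH]1`: 46900 nM

Both numbers come from an ADME assay on HEK293 cells (Homo sapiens) for cytotoxicity, read by MTT assay, with a stated time of 48 h; a higher number here means a weaker inhibitor, a lower number a stronger inhibitor. Among the measured compounds shown here, with only two compounds measured, there is little to place compound 2 against. Compound 2 at 46900 nM and compound 1 at 76200 nM lie within the scatter of each other, so these data do not separate them.

The next compound to consider is compound 3 `Cc1nc(-c2ccccc2)sc1C(=O)CSc1nc(-c2ccc(Cl)c(Cl)c2)c(C#N)c(=O)[nH]1`, which comes from compound 2 by a single change: hydrogen in place of chloro on an aromatic carbon. Hydrogen takes the place of chloro on an aromatic carbon, turning a 4-chlorophenyl group into phenyl.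

For the measured compounds named here, no pair of measured compounds differs in one place only, so nothing here shows directly what this change does in this assay. Going by the values given here, the only guide is the closeness of the two measured values, so no shift beyond the scatter is expected, with no firm direction. The expected 1.2-fold higher number from compound 2 to compound 3 (0.07 log units; within the scatter) is therefore small. For compound 3, the estimated value is 55000 nM, with an expected range from 28000 nM to 110000 nM.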

Compound 3, half-maximal inhibitory concentration: 85100 nM
Compound 3: the middle estimate sits 1.5-fold (0.19 log units) below what was measured; measured number inside the range.
By their numbers in this assay, from the lowest: compounds 2, 1 and 3 (each within the scatter of the next).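

In this assay, among the compounds shown here, the step from a 4-chlorophenyl group to phenyl gives a 1.8-fold higher number from compound 2 to compound 3 (0.26 log units; within the scatter) and so stays within the scatter; this is the first direct look at this position, and it shows that losing this chloro for hydrogen does not move the number by more than repeat measurements would. The other single change now readable, 3,4-dichlorophenyl in place of 4-methoxyphenyl on the other aromatic ring, gives a 1.1-fold higher number from compound 1 to compound 3 (0.05 log units; within the scatter) and is also within the scatter, so neither change separates the compounds in this cytotoxicity measurement. No supporting measurement is available to explain either step.

From the compounds shown here alone, only chloro and hydrogen have been seen at this place on the six-membered aromatic ring, so it remains open whether a quite different group there, such as an amine or a carboxylic acid, would give a step beyond the scatter. Going by these compounds, it also remains open whether the chloro would matter in the same way with 4-methoxyphenyl rather than 3,4-dichlorophenyl on the other side of the core.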